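The compounds below may be only part of what the source reports. "The series", "measured", "known", "first", "only" and "open" are said of these compounds alone.

Working notes on the series.

Three compounds share a core carrying two primary amines and a phenyl group, and differ in the group attached through a linker at one ring position. Compound 1 `Nc1cc(N)c2nc(-c3ccccc3)c(NCc3ccc(Cl)c(Cl)c3)nc2c1` carries a 3,4-dichlorophenyl on a saturated chain carbon bound to a ring nitrogen; in a functional assay on SK-MEL-5 cells (Homo sapiens) for inhibition, read by sulforhodamine B assay, with a stated time of 48 h (on this read-out higher numbers stand for weaker inhibition of growth and lower numbers for stronger inhibition of growth), compound 1 gives 3470 nM. Compound 2 `Nc1cc(N)c2nc(-c3ccccc3)c(Sc3ccc(Cl)c(Cl)c3)nc2c1` joins the same 3,4-dichlorophenyl through sulfur and in this assay compound 2 gives 21400 nM. Compound 3 `CCOC(=O)[C@H](CCC(=O)O)NC(=O)c1ccc(Oc2nc3cc(N)cc(N)c3nc2-c2ccccc2)cc1` carries a larger ether-linked benzamide bearing a glutamate ester, and in this assay compound 3 gives 18200 nM. On these numbers compound 1 stands lowest, with compound 3 nearest and compound 2 furthest, both gaps beyond the scatter.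

Compound 4 `COc1ccc(CNc2nc3cc(N)cc(N)c3nc2-c2ccccc2)cc1OC` is not yet measured. It differs from compound 1 in one place: 3,4-dimethoxyphenyl in place of 3,4-dichlorophenyl on a saturated chain carbon bound to a nitrogen on an aromatic ring. Going by the values given here, no measured pair shows this change, so its effect is unknown here.

Among the compounds with values here, the step from compound 1 to compound 4 is expected to be a modest loss, a 2.3-fold higher number from compound 1 to compound 4 (0.36 log units; beyond the scatter), since the dichlorophenyl-bearing compound 1 gives 3470 nM and no measured compound shows what replacing it does. Compound 4 is estimated at 8000 nM in this assay, with a range from 2500 nM to 25000 nM.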

Compound 4, concentration for 50% growth inhibition: 10000 nM
For compound 4 the middle estimate is 1.3-fold (0.10 log units) below the measured one; low and high end bracket the measured number.
By their numbers in this assay, from the lowest: compound 1; then compounds 4, 3 and 2 (each within the scatter of the next, the first and the last beyond it).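

In this assay, going by these compounds alone, 3,4-dimethoxyphenyl in place of 3,4-dichlorophenyl on a saturated chain carbon bound to a nitrogen on an aromatic ring gives a 2.9-fold higher number from compound 1 to compound 4 (0.46 log units; beyond the scatter), the first step that changes one place while the rest of the structure stays fixed. The six-membered aromatic ring of carbon stays, while the entering group has 2 hydrogen-bond acceptors where the leaving group has 0, so this position responds to a change of the groups on that ring, modestly but beyond the scatter. No measurement shown here accounts for the size or direction of this step.

A single pair cannot separate the loss of the two chlorine atoms from the arrival of the two methoxy groups; an unsubstituted phenyl, or a phenyl with a lone chlorine or a lone methoxy, would be needed to tell these apart. Going by these compounds, it also remains open whether the same exchange gives a step of similar size with the sulfur link of compound 2, and how an amine or a carboxylic acid in place of these groups would read.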